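Removing the Chloro Group from Compound 3

A few compounds are considered here, and "the series" means these few. Any claim that something is new, unique, unknown or untested is made for them only; others in the source may bear on it.

Within the data shown here, in a functional assay on T98G cells (Homo sapiens) for cytotoxicity, read by MTT assay, with a stated time of 48 h (on this read-out higher numbers stand for weaker inhibition and lower numbers for stronger inhibition), compound 3 `CC(=NNC(=S)Nc1ccc(Cl)cc1)c1ccccn1` gives 5.9 nM, the second highest of the three numbers known. Compound 1 `CC(=NNC(=S)Nc1ccccc1F)c1ccccn1` gives 3.1 nM, within the scatter of compound 3, while compound 2 `CC(=NNC(=S)Nc1ccc(I)cc1)c1ccccn1` gives 64 nM. Among the measured compounds shown here, the only single-place step known is an 11-fold lower number from compound 2 to compound 3 (1.04 log units; beyond the scatter). Compound 4 `CC(=NNC(=S)Nc1ccccc1)c1ccccn1` differs from compound 3 by hydrogen in place of chloro on an aromatic carbon, the site being para to a large group. For the measured compounds named here, no measured step removes a halogen altogether, so the earlier step bears on this one only loosely: it shows that exchanging one halogen for another there can move the number markedly. A modest step is therefore expected, a 1.5-fold higher number from compound 3 to compound 4 (0.18 log units; within the scatter). Compound 4 is expected at 9 nM, with a range from 3 nM to 30 nM.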

Compound 4, half-maximal inhibitory concentration: 6.8 nM
Estimate against measurement, compound 4: 1.3-fold (0.12 log units) above; the measured number falls inside the stated range.
By their numbers in this assay, from the lowest: compounds 1, 3 and 4 (each within the scatter of the next, the first and the last beyond it); then compound 2.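

In this assay, removing the chloro group leaves the number essentially unmoved, with a 1.2-fold higher number from compound 3 to compound 4 (0.06 log units; within the scatter), so at this site on the aromatic ring hydrogen serves as well as chloro. The high number of the iodo compound is thus no general feature of a halogen-free or halogen-bearing site: a 9.4-fold lower number from compound 2 to compound 4 (0.97 log units; beyond the scatter) shows hydrogen clearly ahead of iodo. A smaller gap beyond the scatter appears on the fluoro side, with a 2.2-fold higher number from compound 1 to compound 4 (0.34 log units; beyond the scatter). From the compounds shown here alone, whether an amine, a methoxy group or a carboxylic acid at this site would shift the number remains open. Nothing measured here gives a reason for these steps.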